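This account rests on a few compounds, and the source may have more. Where it says the series, first, only, none or still open, it means among the compounds named here.

Series notes. Compound 1 `CCn1c(C(=O)NCC(=O)OC)ccc1C(CC)(CC)c1ccc(OCS(=O)(=O)c2ccccc2)c(C)c1`, compound 2 `CCn1c(C(=O)N[C@@H](C)CO)ccc1C(CC)(CC)c1ccc(OCS(=O)(=O)c2ccccc2)c(C)c1` and compound 3 `CCn1c(C(=O)N[C@H](CO)C(C)C)ccc1C(CC)(CC)c1ccc(OCS(=O)(=O)c2ccccc2)c(C)c1` share one core and differ only in the group on the amide-type nitrogen. In a functional assay on MCF7 cells (Homo sapiens) for antiproliferative activity, read by MTT assay, with a stated time of 24 h (on this read-out lower numbers stand for stronger inhibition and higher numbers for weaker inhibition), compound 1 gives only a limit, > 50000 nM. In this assay compound 2 gives 10800 nM, and compound 3 gives 25500 nM. Compound 2 stands lowest of the two measured numbers; the step from it is a 2.4-fold higher number from compound 2 to compound 3 (0.37 log units; beyond the scatter). The limit for compound 1 is the limit of > 50000 nM in this assay, at which 1 of the 3 values shown sits. The remaining measured steps are an at least 4.6-fold lower number from compound 1 to compound 2 (0.66 log units; beyond the scatter) and an at least 1.9-fold lower number from compound 1 to compound 3 (0.29 log units; that floor lies within the scatter).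

Compound 4 `CCn1c(C(=O)NCC(=O)O)ccc1C(CC)(CC)c1ccc(OCS(=O)(=O)c2ccccc2)c(C)c1` is not yet measured. It differs from compound 2 as follows: carboxymethyl in place of 1-(hydroxymethyl)ethyl on an amide-type nitrogen. For the measured compounds named here, compound 4 thus carries a carboxymethyl group where compound 1 carries a (methoxycarbonyl)methyl group; no measured step covers the acid against the ester. The closest guide is an at least 4.6-fold lower number from compound 1 to compound 2 (0.66 log units; beyond the scatter), which runs the other way. A step back toward higher numbers is therefore expected, possibly reaching the limit again. For compound 4 the expected step is a 3.7-fold higher number from compound 2 to compound 4 (0.57 log units; beyond the scatter). Compound 4 is estimated at 40000 nM, with a range from 15000 nM to 100000 nM.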

Compound 4, half-maximal inhibitory concentration: 33100 nM
The estimate for compound 4 lay 1.2-fold (0.08 log units) above the measured number; the range from low to high includes it.
By their numbers in this assay, from the lowest: compound 2; then compounds 3 and 4 (each within the scatter of the next). At a limit, above all of these: compound 1.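

In this assay, carboxymethyl on the amide-type nitrogen does not hold the level set by 1-(hydroxymethyl)ethyl, with a 3.1-fold higher number from compound 2 to compound 4 (0.49 log units; beyond the scatter), whereas it does not separate from 1-(hydroxymethyl)-2-methylpropyl, with a 1.3-fold higher number from compound 3 to compound 4 (0.11 log units; within the scatter). Hydrogen in place of methyl on the oxygen next to the carbonyl group turns a limit into a measured number, but with an at least 1.5-fold lower number from compound 1 to compound 4 (0.17 log units; that floor lies within the scatter) the acid cannot be ranked ahead of the ester. Compound 1 remains a limit and not a number: the limit of > 50000 nM in this assay, at which 1 of the 4 values shown sits.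

Still open, going by these compounds, is how an amine or a primary amide in place of the carboxymethyl group would read in this assay. Also open, on these data alone, are whether a longer chain ending in a carboxylic acid would follow compound 4, and how the opposite stereocentre of compound 2 would read.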